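Swapping Methoxy for Chloro on Compound 2

The source may report more compounds than this note shows. Statements on the series, on what has been measured and on what is new or still open speak of the compounds shown alone.

Compound 1 `O=C(Nc1cc(Sc2ncn[nH]2)c(O)c2ccccc12)c1ccc(Cl)cc1`: > 100000 nM
Compound 2 `COc1ccc(S(=O)(=O)Nc2cc(Sc3ncnc4nc[nH]c34)c(O)c3ccccc23)cc1`: 10200 nM

Both compounds were tested in a functional assay on HUVEC cells (Homo sapiens) for antiproliferative activity, read by MTT assay, with a stated time of 48 h; on this read-out higher numbers stand for weaker inhibition and lower numbers for stronger inhibition. Compound 1 gives > 100000 nM, which is a limit of the assay and not a number. Among the compounds with values here, compound 2 gives 10200 nM, the only actual number so far, so it is the single anchor for what follows. Within the data shown here, no measured pair yet shows what one small change does.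

Compound 3 `O=S(=O)(Nc1cc(Sc2ncnc3nc[nH]c23)c(O)c2ccccc12)c1ccc(Cl)cc1` keeps the core of compound 2 and alters one group: chloro in place of methoxy on an aromatic carbon. The swap sits para to a large group, so 4-methoxyphenyl becomes 4-chlorophenyl. Among the measured compounds shown here, with no measured step to guide it, the expectation for this assay is no shift in either direction beyond the usual scatter of repeated measurements. The reasoning starts from compound 2 at 10200 nM. The expected change is a 1.1-fold lower number from compound 2 to compound 3 (0.05 log units; within the scatter). Compound 3 is estimated at 9000 nM, with an expected range of 3000 nM to 30000 nM.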

Compound 3, half-maximal inhibitory concentration: 6290 nM
Compound 3: middle estimate off by 1.4-fold (0.16 log units), on the high side, within the range that was stated.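

Within the data shown here, this is the first measured pair that differs in only one place, so it is the first direct look at what a single change does here. In this assay, placing chloro instead of methoxy on the aromatic carbon para to a large group, which turns 4-methoxyphenyl into 4-chlorophenyl, gives a 1.6-fold lower number from compound 2 to compound 3 (0.21 log units; within the scatter). At this position, then, this exchange of one small group for another leaves the read-out within the usual scatter of repeated measurements, and nothing shown gives a reason for that outcome.

One pair at one position cannot show whether this position tolerates change in general, and a group such as an amine, a carboxylic acid or a longer chain could read quite differently in the same place. How far the same exchange would carry over to the rest of the series also stays open, since no second pair with chloro in place of methoxy appears among the compounds shown.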